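This account rests on a few compounds, and the source may have more. Where it says the series, first, only, none or still open, it means among the compounds named here.

Among the measured compounds shown here, compound 1 `O=C(Nc1cccc(-c2oc3cc(-c4ccc(F)cc4)ccc3c(=O)c2O)c1)c1ccc(Br)cc1` gives 9740 nM in a functional assay on HeLa cells (Homo sapiens) for antiproliferative activity, read by CCK-8 assay, with a stated time of 72 h (on this read-out lower numbers stand for stronger inhibition and higher numbers for weaker inhibition), and stands at the lowest of the two numbers known so far. For the measured compounds named here, its only neighbour, compound 2 `O=C(Nc1cccc(-c2oc3cc(-c4ccc(F)cc4)ccc3c(=O)c2O)c1)c1ccc([N+](=O)[O-])cc1`, gives 12300 nM in this assay, so that the step of a 1.3-fold higher number from compound 1 to compound 2 (0.10 log units; within the scatter) lies within the scatter; exchanging the bromo for a nitro at the same place left the number essentially where it was.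

Compound 3 `CCCc1ccc(C(=O)Nc2cccc(-c3oc4cc(-c5ccc(F)cc5)ccc4c(=O)c3O)c2)cc1` differs from compound 1 in a single place: propyl in place of bromo on an aromatic carbon. Going by the values given here, no measured step covers a propyl at this position, and the one step that does touch this place is too small to point in either direction. Any expectation therefore rests on compound 1 alone, with the step from compound 1 to compound 2 suggesting that this position tolerates replacement without a movement beyond the scatter.

Compound 3 is accordingly expected to give 9000 nM in this assay, with a plausible range from 4000 nM to 20000 nM. The expected step is a 1.1-fold lower number from compound 1 to compound 3 (0.03 log units; within the scatter), that is, none beyond the scatter.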

Compound 3, half-maximal inhibitory concentration: 8790 nM
Estimate against measurement, compound 3: 1.0-fold (0.01 log units) above, and the stated range covers the measured number.
By their numbers in this assay, from the lowest: compounds 3, 1 and 2 (each within the scatter of the next).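

In this assay, the change to propyl, which brings 3 heavy atoms where bromo had 1, gives a 1.1-fold lower number from compound 1 to compound 3 (0.04 log units; within the scatter) and so stays within the scatter. Measured against the nitro compound, it gives a 1.4-fold lower number from compound 2 to compound 3 (0.15 log units; within the scatter) and again stays within the scatter. Where the earlier compounds offered a single exchange on this aromatic carbon, para to a large group, three groups now stand there with numbers that cannot be told apart, and none of the listed compounds goes against this; no measurement here speaks to why that is so.

As far as these compounds go, it remains open whether an amine, a carboxylic acid or a longer chain at this place would move the number beyond the scatter. The compounds shown also leave open whether changes elsewhere on the shared core would do so.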